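Chromone series: amine-bearing ether chain, hepatoma cell growth

This account rests on a few compounds, and the source may have more. Where it says the series, first, only, none or still open, it means among the compounds named here.

Measured compounds:
compound 1 `CN1CCN(CCCCOc2c(O)cc3oc(-c4ccccc4)cc(=O)c3c2O)CC1` 93700 nM
compound 2 `CCN(CC)CCCCOc1c(OCc2ccccc2)cc2oc(-c3ccccc3)cc(=O)c2c1O` 2200 nM

Compound 1 stands at the highest number of the two in a functional assay on HepG2 cells (Homo sapiens) for antiproliferative activity, read by MTT assay, with a stated time of 48 h; a higher number here means a weaker inhibitor, a lower number a stronger inhibitor; compound 2 sits well beyond the scatter on the lower side of it. Among the compounds with values here, the two differ in several places at once, so no single-step comparison between measured compounds is available, and what the pair shows is only that a change away from the pattern of compound 1 can lower the number a good deal.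

Compound 3 `O=c1cc(-c2ccccc2)oc2cc(O)c(OCCCN3CCCC3)c(O)c12` is the next member to be measured in this assay. It differs from compound 1 in one place: pyrrolidin-1-yl in place of (4-methylpiperazin-1-yl)methyl on a saturated chain carbon, three bonds along the chain from an oxygen on an aromatic ring. The rest of the shared core and the chain carrying the amine are kept.

Without a measured step of the same kind, the direction is uncertain. The expectation is a moderate step down from compound 1 to compound 3, of the order of a 2.3-fold lower number from compound 1 to compound 3 (0.37 log units; beyond the scatter), somewhat beyond the scatter but not approaching the level of compound 2. Compound 3 is therefore estimated at 40000 nM, within a range of 10000 nM to 120000 nM.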

Compound 3, half-maximal inhibitory concentration: > 100000 nM
Compound 3: a limit, no number; the forecaster's own chance of this, stated with the estimate: 10%; middle value at least 2.5-fold (0.39 log units) away from the limit.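

In this assay compound 3 gives > 100000 nM, which is a limit of the assay and not a number. Pyrrolidin-1-yl in place of (4-methylpiperazin-1-yl)methyl on a saturated chain carbon, three bonds along the chain from an oxygen on an aromatic ring, reads as an at least 1.0-fold higher number from compound 1 to compound 3 (0.02 log units; that floor lies within the scatter), so this exchange shows no lowering of the number, while the true size of the step stays unknown and the floor alone supports no claim of a rise. The new information on this position is therefore one-sided, and the reading of the step is bounded by the assay's limit: the limit of > 100000 nM in this assay, at which 1 of the 3 values shown sits.

Still open, going by these compounds, is whether another amine at this place, such as morpholin-4-yl or piperidin-1-yl, or pyrrolidin-1-yl on a longer chain, would bring the shared core to a measurable number in this assay while the two ring hydroxyl groups of compound 3 are kept. Also open, on these data alone, is which of the several differences between compound 2 and compound 1, the benzyl ether or the diethylamino end of the chain, goes with the lower number of compound 2.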